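The source may hold more compounds than are shown below. What is called first, only, known or untested is meant among the compounds shown, and "the series" means these compounds.

Compound 1, `COc1ccc(C2N=C(SCc3ccc(Cl)cc3)NC(C)=C2C(=O)Nc2ccc(F)cc2)cc1OC`: 15.5%
Compound 2, `COc1ccc(C2N=C(SCc3ccc(F)cc3)NC(C)=C2C(=O)Nc2ccc(F)cc2)cc1OC`: 15.5%
Compound 3, `COc1ccc(C2N=C(SCc3ccc(Cl)cc3)NC(C)=C2C(=O)Nc2ccc(Br)cc2)cc1`: 16.5%

These three compounds were tested in a functional assay on the whole organism (artery, strain albino) with Rattus norvegicus as the target, with a stated time of 120 min, at a dose of 10 mg/kg by the oral route; a higher number here means more inhibition at the dose given (going by the name of the read-out), a lower number less inhibition. The change from compound 1 to compound 2 is fluoro in place of chloro on an aromatic carbon, and this step gave no change at the digits printed from compound 1 to compound 2 (within the scatter). Compound 3 differs from compound 1 in more than one place, and the difference between the two cores is not broken down here. Compound 4, `COc1ccc(C2N=C(SCc3ccc(F)cc3)NC(C)=C2C(=O)Nc2ccc(Br)cc2)cc1`, has not yet been measured in this assay; it differs from compound 3 by fluoro in place of chloro on an aromatic carbon, the same change as between compound 1 and compound 2, at a place described in the same words. Because the earlier instance gave no change at the digits printed from compound 1 to compound 2 (within the scatter), the expected step is no change at the digits printed from compound 3 to compound 4 (within the scatter). Compound 4 is therefore expected to give about 16.5%, most likely between 8% and 25%.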

Compound 4, a percentage reported as inhibition, in the whole organism at one dose (the size of the read-out at that dose, not a potency): 12.9%
Compound 4: middle estimate off by 3.6 percentage points, on the high side; the measured number falls inside the stated range.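

In this assay, the change from 4-chlorobenzyl to 4-fluorobenzyl gave a number 3.6 percentage points lower from compound 3 to compound 4 (within the scatter). Set beside the earlier step, the change carried from one core to the other with no difference that can be told from the scatter: the same change on two cores in this assay, no change at the digits printed (within the scatter) from compound 1 to compound 2 and a number 3.6 percentage points lower (within the scatter) from compound 3 to compound 4, 3.6 percentage points apart, within the scatter of two such steps. Going by these compounds alone, this rests on only two pairs of compounds at a single oral dose, and it does not show that the change would behave the same way on other cores or at other doses.

The compounds shown leave open what a nitrile, a trifluoromethyl, an amine or a carboxylic acid would give at the same place on the ring. They also leave open what a longer chain would give in place of the benzyl group on the sulfur.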